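Amine substituent exchange in the furan-bearing pair

The source may report more compounds than this note shows. Statements on the series, on what has been measured and on what is new or still open speak of the compounds shown alone.

Two compounds of the series have numbers in an assay on isolated protein for inhibition of ubiquitin carboxyl-terminal hydrolase 7 (Homo sapiens), with stated times of 30 min and 2 h; a higher number here means a weaker inhibitor, a lower number a stronger inhibitor. Compound 1 `Cn1nc2c(=O)n(CC3(O)CCN(Cc4ccc(-c5n[nH]c(=O)o5)cc4Cl)CC3)cnc2c1-c1ccc(CN)cc1` gives 171 nM in this assay. For the measured compounds named here, compound 2 `Cn1nc2c(=O)n(CC3(O)CCN(Cc4ccc(-c5ccco5)cc4Cl)CC3)cnc2c1-c1ccc(CNC(=O)C(F)(F)F)cc1` gives 2060 nM in this assay, the higher of the two numbers, and the gap to compound 1 lies beyond the scatter; the two structures differ in more than one place, so no single step is assigned.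

Compound 3 `CC(C)NCc1ccc(-c2c3ncn(CC4(O)CCN(Cc5ccc(-c6ccco6)cc5Cl)CC4)c(=O)c3nn2C)cc1` has not been measured. It differs from compound 2 by isopropyl in place of (trifluoromethyl)carbonyl on an amine nitrogen, the nitrogen thus returning to a basic amine form as in compound 1. Compound 1 carries a free amine at this position and gives 171 nM, so a move in the lower direction beyond the scatter is expected, estimated as a 5.9-fold lower number from compound 2 to compound 3 (0.77 log units; beyond the scatter). For compound 3 the expected value in this assay is 350 nM, with a range from 90 nM to 1400 nM.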

Compound 3, half-maximal inhibitory concentration: 29.1 nM
Beside the measured number, compound 3's estimate is 12-fold (1.08 log units) above it; measured number below the stated range.
By their numbers in this assay, from the lowest: compound 3; then compound 1; then compound 2.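

Within this assay the exchange of (trifluoromethyl)carbonyl for isopropyl on the amine nitrogen gives a 71-fold lower number from compound 2 to compound 3 (1.85 log units; beyond the scatter) and is the only step in the series that can be read at one place. The earlier pair differed in more than one place, so the size of the effect at this nitrogen could not be seen until now; it is large, with the rest of the structure unchanged. No measurement here accounts for the step, so the loss of the carbonyl cannot be separated from the gain of isopropyl.

An acetyl group, a plain ethyl chain or an unsubstituted amine on the same furan-bearing compound would separate those two parts of the change. As far as these compounds go, compound 1 differs from both furan compounds in more than one place, so the effect of its free amine remains open.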